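The Same Amine Swap Tried on a Second Core

The source may hold more compounds than are shown below. What is called first, only, known or untested is meant among the compounds shown, and "the series" means these compounds.

Three measured compounds share one core. Compound 1 `COc1cc2c(Nc3ccc(C#N)cc3)ncnc2cc1OCCCN1CCC(C)CC1` gives 43100 nM in a functional assay on MCF7 cells (Homo sapiens) for antiproliferative activity, read by MTT assay, with a stated time of 72 h; a higher number here means a weaker inhibitor, a lower number a stronger inhibitor. Compound 2 `COc1cc2c(Nc3ccc(C#N)cc3)ncnc2cc1OCCCN1CCN(C)CC1` differs from compound 1 by 4-methylpiperazin-1-yl in place of 4-methylpiperidin-1-yl on a saturated chain carbon, three bonds along the chain from an oxygen on an aromatic ring; in this assay compound 2 gives 71100 nM, a step of a 1.6-fold higher number from compound 1 to compound 2 (0.22 log units; within the scatter). Compound 3 `COc1cc2c(Nc3ccccc3C#N)ncnc2cc1OCCCN1CCC(C)CC1` differs from compound 1 by 2-cyanophenyl in place of 4-cyanophenyl on a nitrogen on an aromatic ring; in this assay compound 3 gives 31900 nM, the step being a 1.4-fold lower number from compound 1 to compound 3 (0.13 log units; within the scatter). Compound 4 `COc1cc2c(Nc3ccccc3C#N)ncnc2cc1OCCCN1CCN(C)CC1` has not yet been measured in this assay. It differs from compound 3 by 4-methylpiperazin-1-yl in place of 4-methylpiperidin-1-yl on a saturated chain carbon, three bonds along the chain from an oxygen on an aromatic ring, which is the same change that separates compound 1 from compound 2, at a place described in the same words for both pairs; only the attachment of the cyanophenyl group on the core is different between the two pairs. Because a 1.6-fold higher number from compound 1 to compound 2 (0.22 log units; within the scatter) lay within the scatter, compound 4 is expected to show a step of a 1.6-fold higher number from compound 3 to compound 4 (0.20 log units; within the scatter). On that basis compound 4 is estimated at 50000 nM in this assay, with a likely range from 25000 nM to 100000 nM.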

Compound 4, half-maximal inhibitory concentration: 17800 nM
Compound 4: middle estimate off by 2.8-fold (0.45 log units), on the high side, and the stated range ends above it.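

In this assay the swap to 4-methylpiperazin-1-yl on the core with 2-cyanophenyl gives a 1.8-fold lower number from compound 3 to compound 4 (0.25 log units; within the scatter), and set beside the same swap on the core with 4-cyanophenyl, it does not carry over unchanged: the same change on two cores in this assay, a 1.6-fold higher number (0.22 log units; within the scatter) from compound 1 to compound 2 and a 1.8-fold lower number (0.25 log units; within the scatter) from compound 3 to compound 4, 3.0-fold (0.47 log units) apart, beyond the scatter of two such steps. Read the other way, the move to 2-cyanophenyl among the 4-methylpiperazin-1-yl compounds gives a 4.0-fold lower number from compound 2 to compound 4 (0.60 log units; beyond the scatter), and this too differs from its counterpart among the 4-methylpiperidin-1-yl compounds: the same change on two cores in this assay, a 1.4-fold lower number (0.13 log units; within the scatter) from compound 1 to compound 3 and a 4.0-fold lower number (0.60 log units; beyond the scatter) from compound 2 to compound 4, 3.0-fold (0.47 log units) apart, beyond the scatter of two such steps. The two changes therefore do not act independently across these four compounds, but this rests on a single set of paired steps, so it gives no general rule for other cores and does not explain the gap.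

The compounds shown leave open whether a morpholin-4-yl group in the same place would also depend on which cyanophenyl group is present. They also leave open whether the gap would persist with a 2-(4-methylpiperazin-1-yl)ethyl chain or with a chlorophenyl group in place of cyanophenyl.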